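The source may report more compounds than this note shows. Statements on the series, on what has been measured and on what is new or still open speak of the compounds shown alone.

Measured so far in a functional assay on CHO cells with adenosine receptor A1 (Homo sapiens) as the target, read by cAMP accumulation and immunoassay, with a stated time of 6 min, tested at 1 uM; a higher number here means a weaker effect of the compound at the concentration tested, a lower number a stronger effect:
compound 1 `Nc1scc(CN2CCN(c3cc(Cl)cc(Cl)c3)CC2)c1C(=O)c1ccc(Cl)cc1` gives -69%
compound 2 `Nc1scc(CN2CCN(c3ccc(F)cc3Cl)CC2)c1C(=O)c1ccc(Cl)cc1` gives -39%
compound 3 `Nc1scc(CN2CCN(c3ccccc3C(F)(F)F)CC2)c1C(=O)c1ccc(Cl)cc1` gives -39%

Going by the values given here, compound 3 stands level with compound 2 at the digits given, the two together the highest of the three numbers, and a number 30 percentage points higher from compound 1 to compound 3 (beyond the scatter) is the one step that sets compound 3 apart. Compound 4 `Nc1scc(CN2CCN(c3cccnc3)CC2)c1C(=O)c1ccc(Cl)cc1` differs from compound 3 at the same place where all three measured compounds vary: pyridin-3-yl in place of 2-(trifluoromethyl)phenyl on an amine nitrogen in a ring. Among the compounds with values here, the steps that bear on this are a number 30 percentage points higher from compound 1 to compound 2 (beyond the scatter), a number 30 percentage points higher from compound 1 to compound 3 (beyond the scatter) and no change at the digits printed from compound 2 to compound 3 (within the scatter); none of them brings in a ring with a hetero atom, so a change at this place has been seen to leave this assay untouched as well as to move it by a modest step. For compound 4 the estimate is -30%, with a range from -60% to -5%. The step of a number 9 percentage points higher from compound 3 to compound 4 (within the scatter) is expected to stay within the scatter.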

Compound 4, a percentage reported as activity, at one concentration (the size of the read-out at that concentration, not a potency): -2.7%
Estimate against measurement, compound 4: 27.3 percentage points below; the measured number lies above the stated range.
By their numbers in this assay, from the lowest: compound 1; then compounds 2 and 3 (each within the scatter of the next); then compound 4.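

In this assay, the first ring with a hetero atom at this place sets compound 4 apart from all three carbon-only aryl compounds: a number 36.3 percentage points higher from compound 3 to compound 4 (beyond the scatter), a number 36.3 percentage points higher from compound 2 to compound 4 (beyond the scatter) and a number 66.3 percentage points higher from compound 1 to compound 4 (beyond the scatter). Change on the amine nitrogen in a ring is therefore not confined to modest steps, and compound 4 has the weakest effect of the four at the concentration tested. No measured evidence bears on this result.

Compound 4 both brings in a ring nitrogen and lacks any chlorine, fluorine or trifluoromethyl substituent, and the compounds shown do not separate these two differences. Unsubstituted phenyl would address the first, and pyridin-4-yl would test the place of the ring nitrogen.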